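The source may report more compounds than this note shows. Statements on the series, on what has been measured and on what is new or still open speak of the compounds shown alone.

Measured compounds:
compound 1, `CC(=O)Nc1ccc(S(=O)(=O)NNC(=O)c2cccnc2Nc2ccc(Cl)cc2)cc1`: > 100000 nM
compound 2, `O=C(NNS(=O)(=O)c1ccc(F)cc1)c1cccnc1Nc1ccc(Cl)cc1Cl`: > 100000 nM

In a functional assay on MOLT-4 cells (Homo sapiens) for antiproliferative activity (a lower number here means that less compound is tolerated, a higher number that more compound is tolerated), compound 1 gives > 100000 nM, which is a limit of the assay rather than a number. Compound 2 likewise gives > 100000 nM in this assay, again only a limit. So compound 1 stands where every value shown stands: the limit of > 100000 nM in this assay, at which 2 of the 2 values shown sit. Going by the values given here, no measured pair here differs in a single place, so no measured step size is available.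

Compound 3, `O=C(NNS(=O)(=O)c1ccc(Cl)cc1Cl)c1cccnc1Nc1ccc(Cl)cc1`, differs from compound 1 by 2,4-dichlorophenyl in place of 4-acetamidophenyl on a sulfonyl sulfur. With both measured compounds sitting at the limit, compound 3 is expected to stay there as well, and the step of a number no higher from compound 1 to compound 3 (the limit leaves the size open) is expected to be none beyond the usual scatter. For compound 3 the estimate in this assay is 100000 nM, within a range from 20000 nM to 500000 nM, most likely reported again only as a limit.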

Compound 3, concentration lethal to 50% of the cells: > 100000 nM
Compound 3 was reported as a limit; the forecaster's own chance of this, stated with the estimate: 75%; the middle value lies on the limit itself.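

Compound 3, like compound 1, is reported only as a limit in this assay, so the step between them cannot be read: the limit of > 100000 nM in this assay, at which 3 of the 3 values shown sit. The compounds shown leave open whether either aryl group on the sulfonyl sulfur differs at all in this read-out.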